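A few compounds are considered here, and "the series" means these few. Any claim that something is new, unique, unknown or untested is made for them only; others in the source may bear on it.

Of the compounds shown here, three sharing one core have been tested in an assay on isolated protein for inhibition of histone deacetylase 8 (Homo sapiens), with a stated time of 1 h (a higher number here means a weaker inhibitor, a lower number a stronger inhibitor), and they differ only in the ring attached to the amide-type nitrogen. Compound 1 `O=C(COc1ccc2cc(/C=C3/SC(=O)NC3=O)ccc2c1)Nc1cccc(F)n1` gives 7200 nM. Compound 2 `O=C(COc1ccc2cc(/C=C3/SC(=O)NC3=O)ccc2c1)Nc1ccc(F)cc1` gives 6600 nM, and a 1.1-fold lower number from compound 1 to compound 2 (0.04 log units; within the scatter). Compound 3 `Cc1ccc(NC(=O)COc2ccc3cc(/C=C4/SC(=O)NC4=O)ccc3c2)cc1Cl` is recorded differently: its result is a limit of the assay, > 50000 nM, rather than a number. Compound 3 therefore stands at the limit of > 50000 nM in this assay, at which 1 of the 3 values shown sits, the weakest position among the values shown, since an at least 6.9-fold higher number from compound 1 to compound 3 (0.84 log units; beyond the scatter) and an at least 7.5-fold higher number from compound 2 to compound 3 (0.87 log units; beyond the scatter).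

The next compound, compound 4 `Cc1cccc(NC(=O)COc2ccc3cc(/C=C4/SC(=O)NC4=O)ccc3c2)n1`, is not yet measured. It differs from compound 3 in one place: 6-methylpyridin-2-yl in place of 3-chloro-4-methylphenyl on an amide-type nitrogen. The ring that enters resembles the 6-fluoropyridin-2-yl of compound 1 more than it resembles the ring it replaces, and the two steps that bear on this change, from compound 1 and from compound 2 to compound 3, both moved the number at least modestly upward. Reversing the same kind of change is expected to move the number downward, back toward the range of compound 1 and compound 2, so an at least 5.5-fold lower number from compound 3 to compound 4 (0.74 log units; beyond the scatter) is the estimated step. Compound 4 is accordingly expected to give about 9000 nM in this assay, within a range of 3000 nM to 35000 nM.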

Compound 4, half-maximal inhibitory concentration: 7500 nM
For compound 4 the middle estimate is 1.2-fold (0.08 log units) above the measured one; the measured number falls inside the stated range.
By their numbers in this assay, from the lowest: compounds 2, 1 and 4 (each within the scatter of the next). At a limit, above all of these: compound 3.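

In this assay, 6-methylpyridin-2-yl in place of 3-chloro-4-methylphenyl on the amide-type nitrogen gives an at least 6.6-fold lower number from compound 3 to compound 4 (0.82 log units; beyond the scatter), so carrying a methyl group does not by itself rule out a measurable number at this position, since compound 4 has one too. Methyl in place of fluoro on an aromatic carbon gives a 1.0-fold higher number from compound 1 to compound 4 (0.02 log units; within the scatter), and 6-methylpyridin-2-yl in place of 4-fluorophenyl gives a 1.1-fold higher number from compound 2 to compound 4 (0.06 log units; within the scatter), so these three different rings cannot be told apart in this assay. Compound 3 alone remains at a limit of this assay and not at a number: the limit of > 50000 nM in this assay, at which 1 of the 4 values shown sits.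

The change from compound 3 to compound 4 removes the chlorine and brings a ring nitrogen in a single step, so the compounds shown cannot say which of the two accounts for the difference. They also leave open whether a small fluoro or methyl group is all this position accepts, or whether a larger or charged group, such as a methoxy group, an amine or a carboxylic acid on the ring, would give a number clearly different from those of compound 1, compound 2 and compound 4.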